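Aryl hydrazones as glucose-6-phosphatase inhibitors: working notes

This account rests on a few compounds, and the source may have more. Where it says the series, first, only, none or still open, it means among the compounds named here.

Compound 1, `COc1ccccc1/C=N/N(Cc1ccccc1)Cc1ccccc1`, in an assay on liver (Sus scrofa) for inhibition of glucose-6-phosphatase catalytic subunit 1 (Homo sapiens), using microsomes; on this read-out lower numbers stand for stronger inhibition and higher numbers for weaker inhibition: > 100000 nM, which is a limit of the assay and not a number.
Compound 2, `Clc1ccc(/C=N/N(Cc2ccccc2)Cc2ccccc2)cc1Cl`: 2000 nM.
Compound 3, `C(=N/N(Cc1ccccc1)Cc1ccccc1)\c1ccco1`: 1100 nM.

Compound 1 sits at the limit (the limit of > 100000 nM in this assay, at which 1 of the 3 values shown sits). Compound 3 gives the lowest of the two numbers shown; compound 2 is nearest to it, and a 1.8-fold lower number from compound 2 to compound 3 (0.26 log units; within the scatter) lies within the scatter, so the two cannot be ordered. Against compound 1 both are set apart by large steps, an at least 50-fold lower number from compound 1 to compound 2 (1.69 log units; beyond the scatter) and an at least 90-fold lower number from compound 1 to compound 3 (1.95 log units; beyond the scatter), each beyond the scatter.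

Compound 4, `Clc1ccc(/C=N/N(Cc2ccccc2)Cc2ccccc2)s1`, is not yet measured. It differs from compound 3 by 5-chlorothiophen-2-yl in place of furan-2-yl on a carbon with a double bond to nitrogen. Within the data shown here, no measured step swaps one five-membered ring for another. Among the measured compounds shown here, the steps that bear on it are an at least 50-fold lower number from compound 1 to compound 2 (1.69 log units; beyond the scatter), where a chlorinated aryl group replaced the methoxyphenyl, and a 1.8-fold lower number from compound 2 to compound 3 (0.26 log units; within the scatter), which stays within the scatter. Since the chlorinated aryl of compound 2 and the furan of compound 3 give numbers within the scatter of each other, a step of no more than the scatter is expected in this assay. The estimate for compound 4 is 1000 nM, with a range of 300 nM to 4000 nM. The expected step is a 1.1-fold lower number from compound 3 to compound 4 (0.04 log units; within the scatter).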

Compound 4, half-maximal inhibitory concentration: 170 nM
Estimate against measurement, compound 4: 5.9-fold (0.77 log units) above, outside the stated range (below it).
By their numbers in this assay, from the lowest: compound 4; then compounds 3 and 2 (each within the scatter of the next). At a limit, above all of these: compound 1.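

In this assay, the position on a carbon with a double bond to nitrogen now separates one five-membered aromatic ring from another: 5-chlorothiophen-2-yl in place of furan-2-yl gives a 6.5-fold lower number from compound 3 to compound 4 (0.81 log units; beyond the scatter) and sets apart two groups of the same ring size, whereas compound 2 and compound 3 could not be ordered. The same group in place of 3,4-dichlorophenyl gives a 12-fold lower number from compound 2 to compound 4 (1.07 log units; beyond the scatter) and, with the steps to compound 1 and compound 3, leaves compound 4 with the lowest number in the series, beyond the scatter of every other compound shown. Compound 1 carries a limit of the assay and not a number, so an at least 580-fold lower number from compound 1 to compound 4 (2.76 log units; beyond the scatter) is a bound only: the limit of > 100000 nM in this assay, at which 1 of the 4 values shown sits.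

The step to compound 4 changes the ring oxygen to sulfur and brings in chlorine at once, so the compounds shown cannot say which of the two accounts for the difference, and neither thiophen-2-yl without chlorine nor 5-chlorofuran-2-yl is among them to part the two. Also open, on these data alone, is how an amine or a carboxylic acid on this ring would read in this assay.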